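The source may hold more compounds than are shown below. What is called first, only, known or untested is meant among the compounds shown, and "the series" means these compounds.

Compound 1 `COC(=O)CC(=O)N1N=C(c2ccc(N3CCN(C)CC3)cc2)CC1c1ccc(N(C)C)cc1` gives -8.3% in a functional assay on HCC1806 cells (Homo sapiens) for inhibition, read by sulforhodamine B assay, tested at 10 uM; on this read-out higher numbers stand for more inhibition at the one concentration tested (going by the name of the read-out) and lower numbers for less inhibition.
Compound 2 `CN1CCN(c2ccc(C3=NN(S(=O)(=O)C4CC4)C(c4ccc(N(C)C)cc4)C3)cc2)CC1` gives 4.7% in this assay.
Compound 3 `CN1CCN(c2ccc(C3=NN(S(=O)(=O)c4ccc(F)cc4)C(c4ccc(N(C)C)cc4)C3)cc2)CC1` gives 92.3% in this assay.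

Among these three, compound 3 stands highest: its nearest neighbour is compound 2, and the step of a number 87.6 percentage points higher from compound 2 to compound 3 (beyond the scatter) was 4-fluorophenyl in place of cyclopropyl on a sulfonyl sulfur. The step of a number 100.6 percentage points higher from compound 1 to compound 3 (beyond the scatter) is larger still. The smaller step of a number 13 percentage points higher from compound 1 to compound 2 (beyond the scatter) shows that a sulfonyl group alone did little; the 4-fluorophenyl on that sulfur brought the large gain.

Compound 4 `CN1CCN(c2ccc(C3=NN(S(=O)(=O)c4ccc(OC(F)(F)F)cc4)C(c4ccc(N(C)C)cc4)C3)cc2)CC1` keeps this arylsulfonyl and changes only its substituent: trifluoromethoxy in place of fluoro on an aromatic carbon, so that 4-fluorophenyl becomes 4-(trifluoromethoxy)phenyl. Among the compounds with values here, no measured step addresses a change on that aromatic ring, so the expectation rests on compound 3 alone: because compound 3 gives 92.3% with the arylsulfonyl intact, compound 4 is expected to stay near it, with a step of about a number 10.3 percentage points lower from compound 3 to compound 4 (beyond the scatter) in this assay, not clearly beyond the scatter. Compound 4 is therefore estimated at 82%, with a range from 45% to 100%.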

Compound 4, a percentage reported as inhibition, at one concentration (the size of the read-out at that concentration, not a potency): 70.8%
Compound 4: the middle estimate sits 11.2 percentage points above what was measured, and the stated range covers the measured number.
By their numbers in this assay, from the lowest: compound 1; then compound 2; then compound 4; then compound 3.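

Within this assay, this aromatic carbon of the arylsulfonyl group proves sensitive to substitution: trifluoromethoxy in place of fluoro gives a modest loss (a number 21.5 percentage points lower from compound 3 to compound 4 (beyond the scatter)). The aryl ring's advantage nevertheless survives this change, as 4-(trifluoromethoxy)phenyl in place of cyclopropyl on the sulfonyl sulfur still gives a large gain (a number 66.1 percentage points higher from compound 2 to compound 4 (beyond the scatter)), so the earlier gain is not confined to 4-fluorophenyl. No evidence is available to explain the difference between fluoro and trifluoromethoxy.

The compounds shown leave open whether a methoxy group, a chlorine atom or a plain hydrogen on that same carbon would read nearer compound 3 or compound 4. They also leave open how an amine or a carboxylic acid there would read, and whether the trend holds with the rest of the shared core changed.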